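Chain-amine homologation on two pyrazinoindole-type cores

The source may hold more compounds than are shown below. What is called first, only, known or untested is meant among the compounds shown, and "the series" means these compounds.

Measured compounds:
compound 1 `CN(C)CCCCn1c(N)c(-c2nc3ccccc3o2)c2nc(C#N)c(C#N)nc21`: 960 nM
compound 2 `CCN(CC)CCCCn1c(N)c(-c2nc3ccccc3o2)c2nc(C#N)c(C#N)nc21`: 1720 nM
compound 3 `CN(C)CCn1c(N)c(-c2nc3cc(Cl)ccc3[nH]2)c2nc(C#N)c(C#N)nc21`: > 50000 nM

In a functional assay on HL60/MX2 cells (Homo sapiens) for antiproliferative activity, read by MTT assay, with a stated time of 48 h (on this read-out higher numbers stand for weaker inhibition and lower numbers for stronger inhibition), compound 1 gives 960 nM. Compound 2 differs from compound 1 only in the side chain, (diethylamino in place of dimethylamino on a saturated chain carbon, four bonds along the chain from an aromatic nitrogen), and compound 2 gives 1720 nM in this assay. The step of a 1.8-fold higher number from compound 1 to compound 2 (0.25 log units; within the scatter) is therefore small and within the scatter of the measurement, so the two values cannot be ordered.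

Compound 3 carries a different core, and the difference between the core of compound 1 and the core of compound 3 is not broken down here. In this assay compound 3 reaches only the limit > 50000 nM, which is a limit of the assay and not a measured number; (the limit of > 50000 nM in this assay, at which 1 of the 3 values shown sits).

Compound 4 `CCN(CC)CCn1c(N)c(-c2nc3cc(Cl)ccc3[nH]2)c2nc(C#N)c(C#N)nc21` is not yet measured. It stands to compound 3 as compound 2 stands to compound 1: diethylamino in place of dimethylamino on a saturated chain carbon, two bonds along the chain from an aromatic nitrogen. This is the same kind of change as that from compound 1 to compound 2, but it is not the same. The place differs: in compound 4 the amine sits two bonds along the chain from an aromatic nitrogen, whereas in compound 2 it sits four bonds along the chain from an aromatic nitrogen. Since the step of a 1.8-fold higher number from compound 1 to compound 2 (0.25 log units; within the scatter) was within the scatter, compound 4 is expected to sit close to compound 3 in this assay, a step that the limit leaves unreadable from compound 3 to compound 4. Compound 4 is thus estimated at 80000 nM, most likely again reported only as a limit, in the range 30000 nM to 300000 nM.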

Compound 4, half-maximal inhibitory concentration: 9290 nM
Compound 4: the middle estimate sits 8.6-fold (0.94 log units) above what was measured; the whole stated range lies above it.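

In this assay, placing diethylamino where dimethylamino stood gives an at least 5.3-fold lower number from compound 3 to compound 4 (0.73 log units; beyond the scatter), so the change does not carry over from one core to the other with the same size: the same change on two cores in this assay, a 1.8-fold higher number (0.25 log units; within the scatter) from compound 1 to compound 2 and an at least 5.3-fold lower number (0.73 log units; beyond the scatter) from compound 3 to compound 4, at least 9.6-fold (0.98 log units) apart, beyond the scatter of two such steps

Compound 3 gives > 50000 nM in this assay, which is a limit of the assay and not a number.

What this does not show is why the two steps part, since the pairs differ both in the core and in the place of the amine, two bonds along the chain from an aromatic nitrogen for compound 3 and compound 4, and four bonds along the chain from an aromatic nitrogen for compound 1 and compound 2, and these compounds do not separate the two differences.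

The compounds shown leave open whether the larger step belongs to the core of compound 3 or to the shorter chain, a question that a four-bond chain on that core, or a two-bond chain on the core of compound 1, would bear on. They also leave open how the series would respond to other groups at the end of the chain, such as dipropylamino or a primary amine.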